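The source may report more compounds than this note shows. Statements on the series, on what has been measured and on what is new or still open speak of the compounds shown alone.

Of the compounds shown here, three sharing one core have been measured in a functional assay on cells (Splenocyte, Mus musculus, strain BALB/c) for inhibition, read by scintillation counting and thymidine incorporation, with stated times of 48 h and 8 h; a lower number here means a stronger inhibitor, a higher number a weaker inhibitor. Compound 1 `c1ccc(-c2noc(Cc3c[nH]c4ccccc34)n2)cc1` reaches only a limit in this assay, > 50000 nM, which is the limit of > 50000 nM in this assay, at which 1 of the 3 values shown sits. Compound 2 `Fc1ccc(-c2nc(Cc3c[nH]c4ccccc34)no2)c(C(F)(F)F)c1` gives 9700 nM. Compound 3 `COc1cc(-c2noc(-c3ccc(NC(=O)OC(C)(C)C)cc3)n2)cc(OC)c1OC` gives 2200 nM, the lowest of the two numbers shown; the nearest, compound 2, sits a gap beyond the scatter higher. Compound 4 `CCCCCCc1ccc(-c2nc(-c3cc(OC)c(OC)c(OC)c3)no2)cc1` differs from compound 3 in one place: hexyl in place of (tert-butoxycarbonyl)amino on an aromatic carbon. For the measured compounds named here, no measured pair shows a change of this kind, so the direction is uncertain; a small move toward a lower number, or none beyond the scatter, is expected, and the expected step from compound 3 to compound 4 is a 1.5-fold lower number from compound 3 to compound 4 (0.17 log units; within the scatter). Compound 4 is therefore estimated at 1500 nM, within a range from 400 nM to 6000 nM.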

Compound 4, half-maximal inhibitory concentration: 22900 nM
Beside the measured number, compound 4's estimate is 15-fold (1.18 log units) below it; the measured number lies above the stated range.
By their numbers in this assay, from the lowest: compound 3; then compound 2; then compound 4. At a limit, above all of these: compound 1.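

In this assay, hexyl in place of (tert-butoxycarbonyl)amino on an aromatic carbon gives a 10-fold higher number from compound 3 to compound 4 (1.02 log units; beyond the scatter), so this position does not tolerate every group it might carry. The change removes a hydrogen-bond donor, two hydrogen-bond acceptors and a double bond at once, and this single step cannot separate them. Nothing measured here accounts for the rise in the number.

Open, going by these compounds, is how a free amine, an acetamide, a carboxylic acid or a shorter alkyl chain would read at this position. Also open, on these data alone, is which part of the (tert-butoxycarbonyl)amino group matters.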